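Phenyl for Methyl on a Fused Core: Expected Potency

The source may hold more compounds than are shown below. What is called first, only, known or untested is meant among the compounds shown, and "the series" means these compounds.

Measured compounds:
Compound 1: `Cc1ccc(Nc2ncnc3sc(Nc4c(Cl)cccc4Cl)nc23)cc1` gives 33 nM in a functional assay on HEK293 cells for antagonist activity at transient receptor potential cation channel subfamily V member 1 (Homo sapiens), read by calcium flux; on this read-out lower numbers stand for stronger inhibition and higher numbers for weaker inhibition.
Compound 2: `Cc1nc(Nc2ccc(C(F)(F)F)c(Cl)c2)c2nc(Nc3c(Cl)cccc3Cl)sc2n1` gives 3 nM in this assay.

Of the two measured compounds, compound 2 stands at the lower number in this assay, and its nearest neighbour, compound 1, sits well above it, by a gap that lies beyond the usual scatter of repeated measurements. Among the measured compounds shown here, no pair of measured compounds differs in just one place, so no measured step is available to calibrate any single change.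

The unmeasured compound 3, `FC(F)(F)c1ccc(Nc2nc(-c3ccccc3)nc3sc(Nc4c(Cl)cccc4Cl)nc23)cc1Cl`, shares the core of compound 2 and differs from it in one place: phenyl in place of methyl on an aromatic carbon. The change sits on an aromatic carbon of a six-membered aromatic ring with two nitrogen, between two ring nitrogen atoms, and keeps the rest of the molecule unchanged. For the measured compounds named here, with no measured precedent for this exchange, the step is expected to be modest, most likely a slight weakening or none beyond the scatter, and the estimated step from compound 2 to compound 3 is a 2.3-fold higher number from compound 2 to compound 3 (0.37 log units; beyond the scatter). Compound 3 is therefore expected to give about 7 nM, with a range from 1.5 nM to 35 nM.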

Compound 3, half-maximal inhibitory concentration: 539 nM
Estimate against measurement, compound 3: 77-fold (1.89 log units) below; the measured number lies above the stated range.
By their numbers in this assay, from the lowest: compound 2; then compound 1; then compound 3.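

In this assay, placing phenyl instead of methyl on the aromatic carbon between two ring nitrogen atoms gives a 180-fold higher number from compound 2 to compound 3 (2.25 log units; beyond the scatter), a large step well beyond the scatter. This is the first single-place comparison among these compounds, and it shows that this position is far from indifferent to what it carries: a methyl group goes with strong inhibition, whereas a phenyl ring, with six carbon atoms in place of one, goes with much weaker inhibition on an otherwise unchanged molecule. Nothing available here explains the size of this loss.

From the compounds shown here alone, one step cannot show whether the weakening sets in gradually as the group grows or belongs to phenyl alone, so it remains open how an ethyl chain, a methoxy group, an amine or a pyridine ring would behave on this same carbon. Going by these compounds, it is also open whether phenyl would have as large an effect in a molecule that differs elsewhere, such as compound 1, which carries a different group on its other amine nitrogen.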